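Replacing the Amide with a Sulfonate on the Shared Core

The source may hold more compounds than are shown below. What is called first, only, known or untested is meant among the compounds shown, and "the series" means these compounds.

Compound 1 `CN1CCC(c2c[nH]c3ccc(NC(=O)C4CC4)nc23)CC1` gives 9.8 nM in an assay for binding affinity to 5-hydroxytryptamine receptor 1F (Homo sapiens), read by radioligand binding; a higher number here means a weaker inhibitor, a lower number a stronger inhibitor. Within the data shown here, compound 2 `CN1CCC(c2c[nH]c3ccc(NC(=O)C(C)(C)C)nc23)CC1` gives 62 nM in this assay, which is the highest of the two numbers measured so far; the single step in the set, a 6.3-fold higher number from compound 1 to compound 2 (0.80 log units; beyond the scatter), is modest but beyond the scatter. Compound 3 `CN1CCC(c2c[nH]c3ccc(OS(C)(=O)=O)nc23)CC1` differs from compound 2 in one place: (methylsulfonyl)oxy in place of ((tert-butyl)carbonyl)amino on an aromatic carbon. Among the measured compounds shown here, no measured step exchanges the amide for a group of another kind at this position, so nothing in the set bears directly on the change. For the measured compounds named here, the step from compound 1 to compound 2 shows only that altering the group on the carbonyl carbon shifts the number modestly. Compound 3 is therefore expected to land a 3.2-fold higher number from compound 2 to compound 3 (0.51 log units; beyond the scatter), with wide uncertainty in both directions. Compound 3 is estimated at 200 nM, within a range from 30 nM to 1500 nM.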

Compound 3, inhibition constant: 4.7 nM
Compound 3: middle estimate off by 43-fold (1.63 log units), on the high side; measured number outside the range, below it.
By their numbers in this assay, from the lowest: compound 3; then compound 1; then compound 2.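

The amide at this position is not required for a low number in this assay: (methylsulfonyl)oxy, with 0 hydrogen-bond donors and 3 hydrogen-bond acceptors, replaces ((tert-butyl)carbonyl)amino with a 13-fold lower number from compound 2 to compound 3 (1.12 log units; beyond the scatter). It also improves on the better of the two amides, (cyclopropylcarbonyl)amino, with a 2.1-fold lower number from compound 1 to compound 3 (0.32 log units; beyond the scatter), which makes compound 3 the strongest of the three in this assay. No supporting evidence accounts for the size of either step.

The compounds shown do not separate the contribution of the linking oxygen from that of the sulfonyl part, which a methylsulfonylamino group, with nitrogen in place of that oxygen, would address. From the compounds shown here alone, how far the result extends to an ethyl or phenyl group on the sulfur also remains open.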